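Trimming an Azido-Hydroxy Side Chain Down to Methyl

The compounds below may be only part of what the source reports. "The series", "measured", "known", "first", "only" and "open" are said of these compounds alone.

Of the compounds shown here, three have so far been tested in a functional assay on the whole organism (B cells) with Mus musculus as the target; on this read-out higher numbers stand for larger maximal responses and lower numbers for smaller maximal responses. Compound 1 `[N-]=[N+]=NCC(O)Cn1c(=O)n(C2OC(CO)[C@@H](O)[C@H]2O)c2nc(N)nc(O)c21` gives 91%. Compound 2 `Cn1c(=O)n([C@@H]2O[C@H](CO)[C@H]3OC(C)(C)O[C@H]32)c2nc(N)nc(O)c21` gives 193%, and compound 3 `C=CCn1c(=O)n([C@@H](CO)OC(CO)CO)c2nc(N)nc(O)c21` gives 0%. Compound 1 thus stands second highest of the three: compound 3 lies beyond the scatter below it, and compound 2 lies beyond the scatter above it. Compound 4 `Cn1c(=O)n(C2OC(CO)[C@@H](O)[C@H]2O)c2nc(N)nc(O)c21` has not yet been measured. It differs from compound 1 in a single place: hydrogen in place of 2-azido-1-hydroxyethyl on a saturated chain carbon bound to an aromatic nitrogen. Among the measured compounds shown here, no measured pair of compounds shows exactly this change, so the size of the step is open. Because compound 2 reaches 193%, responses well above that of compound 1 are clearly possible in this assay, and the step from compound 1 to compound 4 is expected to go upward, a number 59 percentage points higher from compound 1 to compound 4 (beyond the scatter). Compound 4 is estimated at 150%, within a range from 60% to 220%.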

Compound 4, largest response reached (reported as maximal response), in percent of the reference or control that the assay uses: 99%
Estimate against measurement, compound 4: 51 percentage points above; the measured number falls inside the stated range.
By their numbers in this assay, from the lowest: compound 3; then compounds 1 and 4 (each within the scatter of the next); then compound 2.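

Replacing 3-azido-2-hydroxypropyl with methyl in this assay gives a number 8 percentage points higher from compound 1 to compound 4 (within the scatter). The two compounds cannot be told apart on this read-out, so at this place on a saturated chain carbon bound to an aromatic nitrogen, the response of compound 1 does not depend on the azido-hydroxy side chain. No measurement available here offers an explanation for this result. Still open, on these data alone, is whether a different group at this place, such as a plain propyl chain or an amine-bearing chain, would stand apart from compound 4 beyond the scatter.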